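Removing the ring halogen in the arylpiperazine sulfonamide series

A few compounds are considered here, and "the series" means these few. Any claim that something is new, unique, unknown or untested is made for them only; others in the source may bear on it.

Compound 1 `CCCn1c(=O)[nH]c2nc(-c3ccc(S(=O)(=O)N4CCN(c5cccc(Br)c5)CC4)cc3)[nH]c2c1=O` carries a bromo group on the terminal aromatic ring; in an assay on CHO cells for displacement of a labelled ligand from adenosine receptor A1 (Homo sapiens), read by scintillation counting, with a stated time of 90 min, in the presence of a further agent that is not named here (on this read-out lower numbers stand for stronger inhibition and higher numbers for weaker inhibition), compound 1 gives > 1000 nM, which is a limit of the assay and not a number. Compound 2 `CCCn1c(=O)[nH]c2nc(-c3ccc(S(=O)(=O)N4CCN(c5cccc(F)c5)CC4)cc3)[nH]c2c1=O` is the fluoro analogue, and in this assay compound 2 gives > 1000 nM, again only a limit. Compound 3 `CCCn1c(=O)c2[nH]c(-c3ccc(S(=O)(=O)N4CCN(c5ccc(Cl)cc5)CC4)cc3)nc2n(C)c1=O`, with a methylated core and a chloro group, gives in this assay > 1000 nM, also a limit. Among the measured compounds shown here, the one single-change step in the set, a step that the two limits leave unreadable from compound 1 to compound 2, cannot be read because both of its ends sit at the limit of > 1000 nM in this assay, at which 3 of the 3 values shown sit. Compound 2 therefore stands only at a limit, and the other two values shown are limits as well.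

Compound 4 `CCCn1c(=O)[nH]c2nc(-c3ccc(S(=O)(=O)N4CCN(c5ccccc5)CC4)cc3)[nH]c2c1=O` differs from compound 2 by hydrogen in place of fluoro on an aromatic carbon. For the measured compounds named here, no measured step gives the size of such a change, and the only step available is unreadable, so no direction can be taken from it. With every value in the series at the limit, compound 4 is expected to remain there too, and the step that the limit leaves unreadable from compound 2 to compound 4 is expected to lie within the scatter. The estimate for compound 4 in this assay is 3000 nM, with a range from 1000 nM to 10000 nM.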

Compound 4, inhibition constant: 364 nM
Estimate against measurement, compound 4: 8.2-fold (0.92 log units) above; the measured number lies below the stated range.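

In this assay, compound 4 is the only compound shown that gives a number and not a limit, so this place on the terminal ring, meta to a large group, now has a readable response to change: going from 3-fluorophenyl to phenyl gives an at least 2.7-fold lower number from compound 2 to compound 4 (0.43 log units; beyond the scatter). Replacing the bromo group with hydrogen reads the same way, with an at least 2.7-fold lower number from compound 1 to compound 4 (0.43 log units; beyond the scatter). Both sizes are only lower bounds, and the true gaps may be larger, because the halogen compounds give no number: the limit of > 1000 nM in this assay, at which 3 of the 4 values shown sit.

The step between the bromo and fluoro compounds still cannot be read, so the two halogens cannot be ordered against each other, and two halogens at one position do not show whether any substituent here would have the same outcome. Also open, going by these compounds, is whether a methoxy group, an amine or a methyl group at this place would stay near the unsubstituted phenyl or return to the limit, and whether hydrogen in place of chloro would give a similar step on the methylated core of compound 3.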